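The compounds below may be only part of what the source reports. "The series", "measured", "known", "first", "only" and "open" are said of these compounds alone.

Working notes on the series. In an ADME assay on A549 cells (Homo sapiens) for cytotoxicity, read by resazurin assay, with a stated time of 48 h (on this read-out higher numbers stand for lower toxicity in this test and lower numbers for higher toxicity in this test), compound 1 (`CN(C)c1ccc(NC(=O)c2cc(Cl)ccc2O)c(Cl)c1`) gives 85100 nM and compound 2 (`COc1ccc(CNc2ccc(NC(=O)c3cc(Cl)ccc3O)c(Cl)c2)cc1`) gives 80700 nM. Compound 3 (`O=C(Nc1ccc(NCc2cc(F)cc(Cl)c2)cc1Cl)c1cc(Cl)ccc1O`) gives 11100 nM, the lowest of the three numbers. The next compound to be read is compound 4 (`O=C(Nc1ccc(NCc2cccc(Br)n2)cc1Cl)c1cc(Cl)ccc1O`), and the change is 6-bromopyridin-2-yl in place of 3-chloro-5-fluorophenyl on a saturated chain carbon bound to a nitrogen on an aromatic ring. In words, 6-bromopyridin-2-yl stands in place of 3-chloro-5-fluorophenyl on a saturated chain carbon bound to a nitrogen on an aromatic ring.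

For the measured compounds named here, the only measured step at this place is a 7.3-fold lower number from compound 2 to compound 3 (0.86 log units; beyond the scatter), with 3-chloro-5-fluorophenyl entering in place of 4-methoxyphenyl. That step shows that the number can move beyond the scatter with a change here. Going by the values given here, no measured compound carries a 6-bromopyridin-2-yl group, so the direction is only weakly supported. Since compound 4 gives up the group found only in compound 3, a partial return towards compound 2 at 80700 nM is expected. The expected step is a 2.3-fold higher number from compound 3 to compound 4 (0.35 log units; beyond the scatter), smaller than the measured one. For compound 4 the estimated value is 25000 nM, with an expected range of 8000 nM to 70000 nM.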

Compound 4, half-maximal cytotoxic concentration: 92300 nM
Beside the measured number, compound 4's estimate is 3.7-fold (0.57 log units) below it, outside the stated range (above it).
By their numbers in this assay, from the lowest: compound 3; then compounds 2, 1 and 4 (each within the scatter of the next).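

With 6-bromopyridin-2-yl on the saturated chain carbon, this assay shows an 8.3-fold higher number from compound 3 to compound 4 (0.92 log units; beyond the scatter), so the low number of compound 3 is not shared by this halogen-bearing ring. The other two steps, a 1.1-fold higher number from compound 2 to compound 4 (0.06 log units; within the scatter) and a 1.1-fold higher number from compound 1 to compound 4 (0.04 log units; within the scatter), lie within the scatter, which leaves compound 3 alone apart from compounds 1, 2 and 4 in this test. No measurement bearing on the origin of this difference is available.

The step from compound 3 to compound 4 exchanges the ring nitrogen and the halogens together, so the compounds shown cannot say which of these changes goes with the higher number. A 3-bromophenyl group at this place would separate the two, and a 3,5-dichlorophenyl group would show whether the low number of compound 3 extends to a close relative of its ring.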